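This account rests on a few compounds, and the source may have more. Where it says the series, first, only, none or still open, it means among the compounds named here.

Three compounds in this set share one core and differ only in the group on the amide-type nitrogen. Compound 1 `O=C(Nc1cccc(-c2cnco2)c1)C1CCCN(C(=O)c2cc(C(F)(F)F)cc(C(F)(F)F)c2)C1` gives 9% in an ADME assay on PC-3 cells (Homo sapiens) for cytotoxicity, read by WST assay, tested at 100 uM; a lower number here means less inhibition, a higher number more inhibition at the concentration tested (going by the name of the read-out). Compound 2 `CC(=O)c1cccc(NC(=O)C2CCCN(C(=O)c3cc(C(F)(F)F)cc(C(F)(F)F)c3)C2)c1` gives 0% in this assay, and the step between them is a number 9 percentage points lower from compound 1 to compound 2 (within the scatter). Compound 3 `O=C(Nc1cccc(CN2CCCC2)c1)C1CCCN(C(=O)c2cc(C(F)(F)F)cc(C(F)(F)F)c2)C1` gives 51% in this assay, the highest of the three numbers; compound 1 is its nearest neighbour and compound 2 its furthest, both well separated from it.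

Compound 4 `O=C(Nc1ccc(Cl)nc1)C1CCCN(C(=O)c2cc(C(F)(F)F)cc(C(F)(F)F)c2)C1` has not been measured. Its change from compound 3 is 6-chloropyridin-3-yl in place of 3-((pyrrolidin-1-yl)methyl)phenyl on an amide-type nitrogen. The two measured steps that bear on this are the ones leading into compound 3: a number 42 percentage points higher from compound 1 to compound 3 (beyond the scatter) and a number 51 percentage points higher from compound 2 to compound 3 (beyond the scatter). Both gained strongly when the (pyrrolidin-1-yl)methyl group arrived, and compound 4 gives that group up entirely, so the account expects a large step downward in this assay, back toward the level of compounds 1 and 2. The expected step is a number 41 percentage points lower from compound 3 to compound 4 (beyond the scatter). Compound 4 is therefore estimated at 10% in this assay, with a range from 0% to 30%.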

Compound 4, a percentage reported as inhibition, at one concentration (the size of the read-out at that concentration, not a potency): 25%
Estimate against measurement, compound 4: 15 percentage points below, and the stated range covers the measured number.
By their numbers in this assay, from the lowest: compounds 2 and 1 (each within the scatter of the next); then compound 4; then compound 3.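

In this assay the (pyrrolidin-1-yl)methyl group proves not to be the only way to rise clearly above the low pair at this position: losing it gives a number 26 percentage points lower from compound 3 to compound 4 (beyond the scatter) and yet leaves a level of its own. For the compounds shown here, measured against the other two groups on the amide-type nitrogen, 6-chloropyridin-3-yl gives a number 25 percentage points higher from compound 2 to compound 4 (beyond the scatter) and a number 16 percentage points higher from compound 1 to compound 4 (beyond the scatter), so this position now shows a middle level that the earlier compounds, split into a low pair and one high compound, did not show. Nothing at hand accounts for that middle level.

In 6-chloropyridin-3-yl the chlorine and the ring nitrogen enter together while the whole 3-substituted phenyl group leaves, so the compounds shown cannot say which of these parts goes with the number. Also open, going by these compounds, is whether a plain pyridin-3-yl, a fluorine or methoxy in place of the chlorine, or a (pyrrolidin-1-yl)methyl or other amine carried on the pyridine ring would move the number up, down or not at all.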